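The compounds below may be only part of what the source reports. "The series", "measured", "known", "first", "only" and "open" are said of these compounds alone.

Values in an ADME assay on microsomes from liver (Mus musculus) for metabolic stability, using NADPH, with a stated time of 10 min; on this read-out higher numbers stand for a more stable compound and lower numbers for a less stable compound:
compound 1 `NCCCCN(C[C@H]1Cc2ncccc2CN1)[C@H]1CCCc2cccnc21`: 86%
compound 2 `NC/C=C\CN(C[C@H]1Cc2ncccc2CN1)[C@H]1CCCc2cccnc21`: 37%
compound 3 `CN(CCCCN(C[C@H]1Cc2ncccc2CN1)[C@H]1CCCc2cccnc21)C1CCC(F)(F)CC1`: 35%

Compound 3 matches compound 2 within the scatter, and both stand well short of compound 1. Next is compound 4 `c1cnc2c(c1)CN[C@@H](CN(CCCCNC1COC1)[C@H]1CCCc3cccnc31)C2`, with this change: a group of 5 heavy atoms (3 carbon, 1 nitrogen, 1 oxygen; one four-membered non-aromatic ring with 1 hetero atom) in place of a group of 10 heavy atoms (7 carbon, 1 nitrogen, 2 fluorine; one six-membered non-aromatic ring of carbon only), on a saturated chain carbon, four bonds along the chain from an amine nitrogen. The closest measured step is a number 51 percentage points lower from compound 1 to compound 3 (beyond the scatter), which is large and concerns the same place on the chain. The step of a number 49 percentage points lower from compound 1 to compound 2 (beyond the scatter), also large, is a different change and bears on this one only weakly. Among the compounds with values here, the entering (oxetan-3-yl)amino group is the smaller one, so a partial return towards compound 1 is expected, although no measured compound carries this group. The expected step in this assay is upward and beyond the scatter: a number 20 percentage points higher from compound 3 to compound 4 (beyond the scatter). Compound 4 is estimated at 55%, with an expected range of 32% to 80%.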

Compound 4, percent of the compound remaining: 41%
Estimate against measurement, compound 4: 14 percentage points above, and the stated range covers the measured number.
By their numbers in this assay, from the lowest: compounds 3, 2 and 4 (each within the scatter of the next); then compound 1.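

In this assay, the smaller (oxetan-3-yl)amino group at this place on the chain brings no return towards compound 1, with a number 6 percentage points higher from compound 3 to compound 4 (within the scatter) as the reading. The same level holds against the unsaturated chain, with a number 4 percentage points higher from compound 2 to compound 4 (within the scatter) as the reading. Oxetan-3-yl in place of hydrogen on the amine nitrogen is alone enough for a number 45 percentage points lower from compound 1 to compound 4 (beyond the scatter) as the reading, so a group much smaller than the one in compound 3 already gives the full drop.

As far as these compounds go, whether a methyl or acetyl group on that nitrogen would stand with compound 1 or with compound 4 stays open. Nothing available explains these steps.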